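Swapping a Pyrrolidine Amide for a Propanamide: Solubility

This account rests on a few compounds, and the source may have more. Where it says the series, first, only, none or still open, it means among the compounds named here.

Compound 1 `C[C@H](NC(=O)[C@@H]1CCCN1C)c1ccc(NC(=O)N2CC(c3cccnc3)C2)cc1` and compound 3 `C[C@H](NC(=O)[C@@H]1CCCN1C)c1ccc(NC(=O)N2CC(c3cncc(N)c3)C2)cc1` share most of their structure and differ in one spot: amino in place of hydrogen on an aromatic carbon. In a physicochemical assay for solubility, read by LC-MS, in phosphate buffer, with a stated time of 24 h, at pH 6.8 (a lower number here means a less soluble compound, a higher number a more soluble compound), compound 1 gives only a limit of the assay, > 1000000 nM, which is the limit of > 1000000 nM in this assay, at which 1 of the 3 values shown sits. In this assay compound 3 gives 820000 nM. Compound 2 `CCC(=O)N[C@@H](C)c1ccc(NC(=O)N2CC(c3cccnc3)C2)cc1` arises from compound 1 by a single change, (ethyl in place of 1-methylpyrrolidin-2-yl on a carbonyl carbon). In this assay compound 2 gives 700000 nM, and the step is an at least 1.4-fold lower number from compound 1 to compound 2 (0.15 log units; that floor lies within the scatter). The numbers of compound 2 and compound 3 sit within the scatter of each other, so no order can be read between them.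

Compound 4 `CCC(=O)N[C@@H](C)c1ccc(NC(=O)N2CC(c3cncc(N)c3)C2)cc1` has not yet been measured. It arises from compound 3 by the same change, (ethyl in place of 1-methylpyrrolidin-2-yl on a carbonyl carbon), made at a place described in exactly the same words as before. The step of an at least 1.4-fold lower number from compound 1 to compound 2 (0.15 log units; that floor lies within the scatter) is the basis for what follows. The expected step here is a 1.5-fold lower number from compound 3 to compound 4 (0.17 log units; within the scatter), a small move that stays within the scatter. Compound 4 is therefore estimated to give 550000 nM in this assay, with a likely range from 250000 nM to 1000000 nM.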

Compound 4, solubility: 230000 nM
Compound 4: the middle estimate sits 2.4-fold (0.38 log units) above what was measured; the measured number lies below the stated range.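

In this assay, putting ethyl in place of 1-methylpyrrolidin-2-yl on a carbonyl carbon gives a 3.6-fold lower number from compound 3 to compound 4 (0.55 log units; beyond the scatter), a modest step on the core that carries the amino group. Read the other way around the same set of compounds, amino in place of hydrogen on an aromatic carbon gives a 3.0-fold lower number from compound 2 to compound 4 (0.48 log units; beyond the scatter), so the two changes taken together end at the lowest number of the measured values that can be compared. How far the ethyl change carries from one core to the other cannot be judged, because the step on the core without the amino group starts from compound 1, which gives only a limit and not a number: the limit of > 1000000 nM in this assay, at which 1 of the 4 values shown sits.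

Going by these compounds, whether a longer chain such as butyl, or a chain ending in a primary amine or a carboxylic acid, would give a similar step on either core stays open. The four compounds also do not tell why the step has the size it has.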